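This account rests on a few compounds, and the source may have more. Where it says the series, first, only, none or still open, it means among the compounds named here.

Working notes on the series. Compound 1 `O=C(c1ccccc1)N1CCn2nc(-c3cccnc3)cc2C1` and compound 2 `Cc1cccnc1-c1cc2n(n1)CCN(C(=O)c1ccccc1)C2` share a core that carries a pyridyl group on an aromatic carbon of a five-membered ring. In a functional assay on HEK293 cells for negative allosteric modulation of metabotropic glutamate receptor 5 (Homo sapiens), read by calcium flux, with a stated time of 20 min (a lower number here means a stronger inhibitor, a higher number a weaker inhibitor), compound 1 gives only a limit of the assay, > 10000 nM. In this assay compound 2 likewise gives only a limit, > 10000 nM. The step that the two limits leave unreadable from compound 1 to compound 2 cannot be read, since both ends sit at the limit (the limit of > 10000 nM in this assay, at which 2 of the 2 values shown sit). Among the measured compounds shown here, compound 2 thus stands nowhere on a scale: only its limit is known, and the one further value shown is a limit as well. Compound 3 `Cc1ccc(-c2cc3n(n2)CCN(C(=O)c2ccccc2)C3)nc1` differs from compound 2 by 5-methylpyridin-2-yl in place of 3-methylpyridin-2-yl on an aromatic carbon; the two have the same atoms, joined differently. No measured step bears on this change: the only step shown is the unreadable one, and no measured compound carries a 5-methylpyridin-2-yl group. The expected step of an at least 1.2-fold lower number from compound 2 to compound 3 (0.09 log units; that floor lies within the scatter) in this assay is therefore given with wide bounds and no direction beyond the scatter. Compound 3 is estimated at 8000 nM, between 1000 nM and 30000 nM, with a sizeable chance that only a limit is reported.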

Compound 3, half-maximal inhibitory concentration: 244 nM
The estimate for compound 3 lay 33-fold (1.52 log units) above the measured number, outside the stated range (below it).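

The exchange of 3-methylpyridin-2-yl for 5-methylpyridin-2-yl gives an at least 40-fold lower number from compound 2 to compound 3 (1.61 log units; beyond the scatter) in this assay, so with the same atoms joined differently, this position on the five-membered aromatic ring goes from a limit of the assay to a measurable number. The exchange of pyridin-3-yl for 5-methylpyridin-2-yl gives an at least 40-fold lower number from compound 1 to compound 3 (1.61 log units; beyond the scatter), a second large step at the same position. The shared core can therefore support activity in this assay, and the presence of a methylpyridinyl group alone does not secure it, as compound 2 also carries one and remains at a limit.

The true size of both steps stays open, and the steps between limits cannot be read: the limit of > 10000 nM in this assay, at which 2 of the 3 values shown sit. The compounds shown also leave open whether the methyl group of 5-methylpyridin-2-yl is needed at all, and how a plain pyridin-2-yl group, or a chlorine atom or a methoxy group in place of that methyl, would read in this assay.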